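Swapping a sulfonyl aryl group on a boronic acid series

This account rests on a few compounds, and the source may have more. Where it says the series, first, only, none or still open, it means among the compounds named here.

Three boronic acid compounds have been measured in a functional assay on MDA-MB-231 cells (Homo sapiens) for antiproliferative activity, read by sulforhodamine B assay, with a stated time of 72 h; on this read-out higher numbers stand for weaker inhibition and lower numbers for stronger inhibition. Compound 1 `Cc1ccc(S(=O)(=O)Nc2cc(SCC(=O)N[C@@H](CC(C)C)B(O)O)c(O)c3ccccc23)cc1` gives 14000 nM in this assay. Compound 2 `CC(C)C[C@H](NC(=O)CSc1cc(NS(=O)(=O)c2cccs2)c2ccccc2c1O)B(O)O` gives 6520 nM, and compound 3 `Cc1ccc(S(=O)(=O)Nc2cc(SC(C)C(=O)N[C@@H](CC(C)C)B(O)O)c(O)c3ccccc23)cc1` gives 8130 nM. Compound 4 `CC(C)C[C@H](NC(=O)C(C)Sc1cc(NS(=O)(=O)c2cccs2)c2ccccc2c1O)B(O)O` is not yet measured.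

Compound 2 arises from compound 1 by one change: thiophen-2-yl in place of 4-methylphenyl on a sulfonyl sulfur. Going by the values given here, that step, a 2.1-fold lower number from compound 1 to compound 2 (0.33 log units; beyond the scatter), is the only measured example of this exchange. Compound 3 arises from compound 1 by a different change, (methyl in place of hydrogen on a saturated chain carbon bound to a carbonyl carbon and a sulfur), and its step, a 1.7-fold lower number from compound 1 to compound 3 (0.24 log units; within the scatter), stays inside the usual variation of repeated measurements, so compound 3 and compound 1 cannot be ordered against each other.

Compound 4 relates to compound 3 exactly as compound 2 relates to compound 1: thiophen-2-yl in place of 4-methylphenyl on a sulfonyl sulfur. The surroundings of the change are the same in both pairs, so this is the same change made on a core that differs only in the way just described. The expectation for this assay is a step of a 2.1-fold lower number from compound 3 to compound 4 (0.32 log units; beyond the scatter), on the grounds that the same exchange already produced a 2.1-fold lower number from compound 1 to compound 2 (0.33 log units; beyond the scatter) when made on compound 1. The core difference, a single methyl, gave no step beyond the scatter, which supports carrying the earlier step over rather than adjusting it. For compound 4 the estimated value in this assay is 3900 nM, with a likely range from 1800 nM to 8500 nM.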

Compound 4, half-maximal inhibitory concentration: 7450 nM
For compound 4 the middle estimate is 1.9-fold (0.28 log units) below the measured one; low and high end bracket the measured number.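

In this assay, thiophen-2-yl in place of 4-methylphenyl on the sulfonyl sulfur gives a 1.1-fold lower number from compound 3 to compound 4 (0.04 log units; within the scatter), and set beside the earlier example of this exchange, the new step cannot be told apart from it: the same change on two cores in this assay, a 2.1-fold lower number (0.33 log units; beyond the scatter) from compound 1 to compound 2 and a 1.1-fold lower number (0.04 log units; within the scatter) from compound 3 to compound 4, 2.0-fold (0.29 log units) apart, within the scatter of two such steps

The methyl on the saturated chain carbon, read on the two thiophen-2-yl compounds, gives a 1.1-fold higher number from compound 2 to compound 4 (0.06 log units; within the scatter), and this step also agrees with its earlier counterpart: the same change on two cores in this assay, a 1.7-fold lower number (0.24 log units; within the scatter) from compound 1 to compound 3 and a 1.1-fold higher number (0.06 log units; within the scatter) from compound 2 to compound 4, 2.0-fold (0.29 log units) apart, within the scatter of two such steps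

So the four compounds are consistent with each change behaving alike on both cores, but they do not prove that the sulfonyl exchange carries over: it lies beyond the scatter on one core and within it on the other, and each core offers only a single pair.

The compounds shown leave open whether another group on the sulfonyl sulfur, such as a plain phenyl, a 4-chlorophenyl or a furan-2-yl, would give a step beyond the scatter on both cores. Also open, on these data alone, is what a longer chain, such as an ethyl in place of the methyl, would do on the saturated chain carbon bound to the carbonyl carbon and the sulfur.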